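The compounds below may be only part of what the source reports. "The series", "measured", "known", "first", "only" and "open" are said of these compounds alone.

Working notes on the series. Compound 1 `COc1ccc(F)cc1CNCCCNc1ccnc2cc(Cc3ccc(C#N)cc3)ccc12` is the reference point. In an ADME assay for permeability, using PAMPA, with a stated time of 30 min, at pH 7.4 (on this read-out higher numbers stand for higher permeability and lower numbers for lower permeability), compound 1 gives 23 10^-6 cm/s. The only other measured member, compound 2 `COc1cccc(CNCCCNc2ccnc3cc(CCC(C)C)ccc23)c1O`, gives in this assay a value of 23 10^-6 cm/s; on the digits shown compound 1 stands level with compound 2, and the gap between them lies within the scatter, so nothing more can be read from the pair. Among the measured compounds shown here, no two measured compounds differ in one place, so no measured step exists to carry over.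

Compound 3 `COc1ccc(-c2ccc3c(NCCCNCc4cc(F)ccc4OC)ccnc3c2)cc1` is not yet measured. It differs from compound 1 as follows: 4-methoxyphenyl in place of 4-cyanobenzyl on an aromatic carbon. The group that leaves carries a triple bond outside aromatic rings, the group that enters carries none, and the counts of hydrogen-bond donors and acceptors given for the two groups match. For the measured compounds named here, compound 1 gives 23 10^-6 cm/s in this assay, and no reference step exists for this change. The step of a 1.2-fold higher number from compound 1 to compound 3 (0.07 log units; within the scatter) is therefore expected to be small, within the scatter, leaning slightly upward. Compound 3 is estimated at 27 10^-6 cm/s in this assay, with a range from 13 10^-6 cm/s to 55 10^-6 cm/s.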

Compound 3, apparent permeability: 237 10^-6 cm/s
The estimate for compound 3 lay 8.8-fold (0.94 log units) below the measured number, outside the stated range (above it).
By their numbers in this assay, from the lowest: compounds 1 and 2 (each within the scatter of the next); then compound 3.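

At the aromatic carbon of the shared core, meta to a fused ring and para to a fused ring, the read-out in this assay is not indifferent to the group carried: 4-methoxyphenyl in place of 4-cyanobenzyl gives a 10-fold higher number from compound 1 to compound 3 (1.01 log units; beyond the scatter) and thereby opens the first spread in the series beyond the scatter. The step arises although the two groups match in their counts of hydrogen-bond donors and acceptors, carry no net charge and each hold one six-membered aromatic ring of carbon only, so these counts do not track the read-out in this pair. The groups do differ in other ways, since 4-cyanobenzyl holds the nitrile and the carbon link to the core while 4-methoxyphenyl holds the methoxy group and sits directly on the core, and no measurement here assigns the step to any of these differences.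

The compounds shown leave these differences bundled in a single exchange, and 4-methoxybenzyl or 4-cyanophenyl at this place would pull them apart. Going by these compounds, how far the read-out moves with an amine or a carboxylic acid on the same ring also remains open.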